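Trading fluoro for methoxy on compound 1

The compounds below may be only part of what the source reports. "The series", "measured", "known", "first", "only" and "open" are said of these compounds alone.

Compound 1 `O=C(Nc1ccc([N+](=O)[O-])cc1Cl)c1cc(F)ccc1O` is the starting point. Within the data shown here, in a physicochemical assay for solubility (a higher number here means a more soluble compound, a lower number a less soluble compound), compound 1 gives 3.3 ug/mL and that is the only true number so far. In this assay compound 2 `COc1ccc(C(=O)Nc2ccc([N+](=O)[O-])cc2Cl)c(O)c1` reads < 1 ug/mL which is a limit of the assay and not a number.

Compound 3 `COc1ccc(O)c(C(=O)Nc2ccc([N+](=O)[O-])cc2Cl)c1` has not been measured yet. The swap methoxy in place of fluoro on an aromatic carbon from compound 1 puts methoxy in place of fluoro on an aromatic carbon, meta to a large group and para to a hydroxy group. Among the measured compounds shown here, no measured pair in this small set shows what such a change does, so any forecast has little to rest on. For the measured compounds named here, the only other guide is compound 2 at < 1 ug/mL which is again a limit, so a modest fall in this assay is expected rather than a rise. The estimated move a 2.1-fold lower number from compound 1 to compound 3 (0.31 log units; beyond the scatter) is a fall that may only just clear the usual scatter, and a reading at the limit remains possible. Compound 3 is expected at 1.6 ug/mL with an estimated range from 0.6 ug/mL to 4 ug/mL for this measurement.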

Compound 3, solubility: 2.1 ug/mL
The estimate for compound 3 lay 1.3-fold (0.12 log units) below the measured number, within the range that was stated.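

Methoxy in place of fluoro on an aromatic carbon, meta to a large group and para to a hydroxy group, now has a measured result: in this assay the swap gives a 1.6-fold lower number from compound 1 to compound 3 (0.20 log units; within the scatter). This means that compound 1 and compound 3 cannot be told apart here, even though the entering methoxy brings 2 heavy atoms where the leaving fluoro had 1, and compound 3 gives a true number rather than a limit. Compound 2 remains a limit and not a number, and it is the only compound shown that reads this way: the limit of < 1 ug/mL in this assay, at which 1 of the 3 values shown sits.

As far as these compounds go, only fluoro and methoxy are seen at this position, so it remains open whether an amine, a carboxylic acid or a longer chain there would shift the solubility read-out in this assay beyond the scatter. One pair of compounds also cannot show whether the same swap would give a similar result on a core other than that of compound 1.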